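A few compounds are considered here, and "the series" means these few. Any claim that something is new, unique, unknown or untested is made for them only; others in the source may bear on it.

In a functional assay on A549 cells (Homo sapiens) for antiproliferative activity, read by MTT assay, with a stated time of 48 h (on this read-out higher numbers stand for weaker inhibition and lower numbers for stronger inhibition), compound 1 `CCCCCCC1(O)C(=O)Nc2ccc(Nc3ccc(OC)cc3)cc21` gives 18600 nM. Compound 3 `CCCCCCC1(O)C(=O)Nc2ccc(Nc3ccc(Cl)cc3)cc21` is built on the same frame but differs from compound 1 in one place: chloro in place of methoxy on an aromatic carbon. In this assay, for the measured compounds named here, compound 3 gives 5400 nM, which makes the step of a 3.4-fold lower number from compound 1 to compound 3 (0.54 log units; beyond the scatter) the only measured step here that clears the usual scatter; compound 3 thus gives the lowest number of the two numbers reported.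

Compound 2 `COc1ccc(Nc2ccc3c(c2)C(O)(Cc2ccccc2)C(=O)N3)cc1` is compound 1 with a single change, (phenyl in place of pentyl on a saturated chain carbon bound to a saturated ring carbon). For compound 2, this assay reports only a limit, > 30000 nM, and not a number. The step of an at least 1.6-fold higher number from compound 1 to compound 2 (0.20 log units; that floor lies within the scatter) is therefore known only as a floor, and that floor rests on (the limit of > 30000 nM in this assay, at which 1 of the 3 values shown sits).

Compound 4 `O=C1Nc2ccc(Nc3ccc(Cl)cc3)cc2C1(O)Cc1ccccc1` has not yet been measured. It stands to compound 3 exactly as compound 2 stands to compound 1: the change is phenyl in place of pentyl on a saturated chain carbon bound to a saturated ring carbon, made at the same place, so it is the same change. The two pairs differ only in their cores, the difference being chloro in place of methoxy, as described above.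

Compound 4 is expected to give about 13000 nM in this assay, most likely between 6000 nM and 30000 nM. That estimate means a step of a 2.4-fold higher number from compound 3 to compound 4 (0.38 log units; beyond the scatter), and it rests on the floor set by an at least 1.6-fold higher number from compound 1 to compound 2 (0.20 log units; that floor lies within the scatter), which points toward a higher number after this change, with the size of the step above that floor unknown.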

Compound 4, half-maximal inhibitory concentration: 3100 nM
For compound 4 the middle estimate is 4.2-fold (0.62 log units) above the measured one; measured number outside the range, below it.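

In this assay, phenyl in place of pentyl on the chloro-bearing core gives a 1.7-fold lower number from compound 3 to compound 4 (0.24 log units; within the scatter), a step too small to separate the two compounds, and it does not match the step seen on the methoxy-bearing core: the same change on two cores in this assay, an at least 1.6-fold higher number (0.20 log units; that floor lies within the scatter) from compound 1 to compound 2 and a 1.7-fold lower number (0.24 log units; within the scatter) from compound 3 to compound 4, at least 2.8-fold (0.44 log units) apart, beyond the scatter of two such steps

The same four compounds, read the other way, show chloro in place of methoxy giving an at least 9.6-fold lower number from compound 2 to compound 4 (0.98 log units; beyond the scatter), a larger step on the phenyl-bearing compounds than on the pentyl-bearing ones: the same change on two cores in this assay, a 3.4-fold lower number (0.54 log units; beyond the scatter) from compound 1 to compound 3 and an at least 9.6-fold lower number (0.98 log units; beyond the scatter) from compound 2 to compound 4, at least 2.8-fold (0.44 log units) apart, beyond the scatter of two such steps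

So this change does not carry over unchanged between these two cores, yet the comparison rests on compound 2, whose value is only a limit, and it shows neither the full size of the mismatch nor how the change would behave on any third core: the limit of > 30000 nM in this assay, at which 1 of the 4 values shown sits.

The compounds shown leave open how a longer chain such as octyl would fare in place of pentyl or phenyl on either core. They also leave open whether fluoro or an amine in place of chloro would follow the chloro-bearing or the methoxy-bearing pattern.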